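This account rests on a few compounds, and the source may have more. Where it says the series, first, only, none or still open, it means among the compounds named here.

Compound 1 `COc1cc(-n2ncnc2-c2ccc(C)cc2)cc(OC)c1OC`: 1100 nM
Compound 2 `COc1cc(-c2ncnn2-c2cccc(N)c2)cc(OC)c1OC`: > 10000 nM
Compound 3 `COc1cc(-c2ncnn2-c2ccccc2)cc(OC)c1OC`: > 10000 nM

For the measured compounds named here, in a functional assay on A549 cells (Homo sapiens) for antiproliferative activity, read by MTT assay, with a stated time of 72 h (on this read-out lower numbers stand for stronger inhibition and higher numbers for weaker inhibition), compound 1 gives the only number among the three measured compounds, 1100 nM. For compound 2 the assay reports only a limit. For compound 3 it likewise reports only a limit. The step that the two limits leave unreadable from compound 2 to compound 3 is therefore unreadable, since both values sit at the limit of > 10000 nM in this assay, at which 2 of the 3 values shown sit.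

Compound 4 `COc1cc(-n2ncnc2-c2cccc(F)c2)cc(OC)c1OC` differs from compound 1 by 3-fluorophenyl in place of 4-methylphenyl on an aromatic carbon. No measured step concerns this exchange, and nothing shown speaks for a shift beyond the usual scatter in this assay. Compound 4 is therefore expected to give about 1500 nM, between 500 nM and 5000 nM. The expected step is a 1.4-fold higher number from compound 1 to compound 4 (0.13 log units; within the scatter).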

Compound 4, half-maximal inhibitory concentration: > 10000 nM
Compound 4 was reported as a limit; the forecaster's own chance of this, stated with the estimate: 10%; middle value at least 6.6-fold (0.82 log units) away from the limit.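

In this assay, 3-fluorophenyl in place of 4-methylphenyl on the aromatic carbon between two ring nitrogen atoms gives an at least 9.0-fold higher number from compound 1 to compound 4 (0.95 log units; beyond the scatter). For the compounds shown here, this is the first readable step at this position, and it shows that the number responds to the aryl group here even though both groups have 7 heavy atoms. Compound 4 gives > 10000 nM, which is a limit and not a number, and it joins the compounds at that limit: the limit of > 10000 nM in this assay, at which 3 of the 4 values shown sit.

Going by these compounds, what stays open is whether the loss of the 4-methyl group or the arrival of the 3-fluoro group matters. Neither 4-fluorophenyl nor 3-methylphenyl at this place is shown, so the two changes cannot be separated.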